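Swapping an Aryl Group for Cyclopentyl on the Shared Core

The source may report more compounds than this note shows. Statements on the series, on what has been measured and on what is new or still open speak of the compounds shown alone.

Of the compounds shown here, three built on one shared core have been tested in a functional assay on T-24 cells (Homo sapiens) for antiproliferative activity, read by MTT assay, with a stated time of 48 h; on this read-out higher numbers stand for weaker inhibition and lower numbers for stronger inhibition. Compound 1, `Cc1ccc(NC(=O)Nc2cccc(CNc3nccnc3Cl)c2)cc1Cl`, gives 7390 nM. Compound 2, `CCc1ccc(NC(=O)Nc2cccc(CNc3nccnc3Cl)c2)c(CC)c1`, gives 6390 nM, and compound 3, `CC(C)(C)c1ccc(NC(=O)Nc2cccc(CNc3nccnc3Cl)c2)cc1`, gives 6010 nM. The three numbers lie within the usual scatter of one another, so none of them can be set apart from the rest; all three show only weak inhibition, and compound 1 is the one taken as the starting point here.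

Compound 4, `O=C(Nc1cccc(CNc2nccnc2Cl)c1)NC1CCCC1`, has not yet been measured. It differs from compound 1 in a single place: cyclopentyl in place of 3-chloro-4-methylphenyl on an amide-type nitrogen. A six-membered aromatic ring of carbon only leaves, and a five-membered non-aromatic ring of carbon only enters, on an amide-type nitrogen whose other neighbour is a carbonyl carbon. Among the measured compounds shown here, no pair of measured compounds shows this kind of change, so the data give no direct guide to its size. Compounds 1, 2 and 3 all keep an aromatic ring at this place, and the step to a non-aromatic ring is expected to weaken inhibition somewhat, a 1.8-fold higher number from compound 1 to compound 4 (0.25 log units; within the scatter), though a result inside the scatter cannot be ruled out. On that basis compound 4 is estimated at 13000 nM, with a range from 5000 nM to 35000 nM.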

Compound 4, half-maximal inhibitory concentration: > 40000 nM
Compound 4: a limit, no number; the forecaster's own chance of this, stated with the estimate: 25%; middle value at least 3.0-fold (0.48 log units) away from the limit.
By their numbers in this assay, from the lowest: compounds 3, 2 and 1 (each within the scatter of the next). At a limit, above all of these: compound 4.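

In this assay, compound 4 gives > 40000 nM, which is a limit of the assay and not a number. Cyclopentyl in place of 3-chloro-4-methylphenyl on the amide-type nitrogen brings an at least 5.4-fold higher number from compound 1 to compound 4 (0.73 log units; beyond the scatter), so this place on the shared core does respond to a change, which compounds 1, 2 and 3, all with a six-membered aromatic ring of carbon only at this place and all within the scatter of one another, could not show. The true size of this step stays unknown, and the printed figure is only the smallest it can be: the limit of > 40000 nM in this assay, at which 1 of the 4 values shown sits.

This single change removes the aromatic ring, shortens the ring from six members to five, and takes away the chlorine and the methyl all at once, so the compounds shown cannot say which of these matters. Plain phenyl would test the loss of the chlorine and the methyl alone, while cyclohexyl would keep the six-membered ring without its aromatic character, and the effect of either group on inhibition remains open.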